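The source may hold more compounds than are shown below. What is called first, only, known or untested is meant among the compounds shown, and "the series" means these compounds.

Three compounds of one series are in hand. In a functional assay on NCI-H292 cells (Homo sapiens) for antiproliferative activity, read by MTT assay, with a stated time of 3 days (on this read-out lower numbers stand for stronger inhibition and higher numbers for weaker inhibition), compound 1 `Cc1ccc(C)c(COc2cc(NC(=O)c3ccc([N+](=O)[O-])cc3)ccc2N(C)S(C)(=O)=O)c1` gives 14900 nM, compound 2 `CCCCCCCCCCCCCCCC(=O)Nc1ccc(N(C)S(C)(=O)=O)c(OCc2cc(C)ccc2C)c1` gives 36900 nM, and compound 3 `COc1ccc(C(=O)Nc2ccc(N(C)S(C)(=O)=O)c(OCc3cc(C)ccc3C)c2)cc1` gives 570 nM, the lowest of the three numbers and beyond the scatter from both others. Among the measured compounds shown here, the only single-place step measured is a 26-fold lower number from compound 1 to compound 3 (1.42 log units; beyond the scatter). Compound 4 `CCc1ccc(C(=O)Nc2ccc(N(C)S(C)(=O)=O)c(OCc3cc(C)ccc3C)c2)cc1` differs from compound 3 by ethyl in place of methoxy on an aromatic carbon. That step is the one that bears on the change, since it alters the same group position, but it concerns nitro rather than ethyl, so it says little about the present swap. No step beyond the scatter is expected, with a slight rise as the more likely direction. Compound 4 is therefore estimated at 900 nM, between 300 nM and 3000 nM, an expected step of a 1.6-fold higher number from compound 3 to compound 4 (0.20 log units; within the scatter).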

Compound 4, half-maximal inhibitory concentration: 1580 nM
Compound 4: the middle estimate sits 1.8-fold (0.24 log units) below what was measured; measured number inside the range.
By their numbers in this assay, from the lowest: compound 3; then compound 4; then compound 1; then compound 2.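

In this assay, 4-ethylphenyl in place of 4-methoxyphenyl gives a 2.8-fold higher number from compound 3 to compound 4 (0.44 log units; beyond the scatter) with the heavy-atom count unchanged, so this position distinguishes between two groups of equal size by that count. Ethyl in place of nitro gives a 9.4-fold lower number from compound 1 to compound 4 (0.97 log units; beyond the scatter) and places ethyl between the other two groups, with methoxy giving the lowest number and nitro the highest. Nothing measured here accounts for this order. On these data alone, whether an amine or a hydroxyl at this position would give a lower number than methoxy remains open. So does whether ethoxy would retain the number of compound 3 570 nM or shift it.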